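Working notes: 2-bromophenyl to 2-chlorophenyl in the series

A few compounds are considered here, and "the series" means these few. Any claim that something is new, unique, unknown or untested is made for them only; others in the source may bear on it.

- compound 1 `NC1=NC2(CCSCC2)N(OCCCOc2ccc(Cl)c(Cl)c2)C(N)=N1` at 10 nM
- compound 2 `NC1=NC2(CCSCC2)N(OCCCOc2cccc(Cl)c2Cl)C(N)=N1` at 1 nM
- compound 3 `NC1=NC2(CCSCC2)N(OCCCOc2ccccc2Br)C(N)=N1` at 10 nM

All three values come from a functional assay on MDA-MB-231 cells (Homo sapiens) for antiproliferative activity, read by MTT assay, with a stated time of 72 h (a lower number here means a stronger inhibitor, a higher number a weaker inhibitor), and place compound 3 level with compound 1 at the digits shown, together the highest of the three numbers. Compound 2 holds the lowest number.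

The next step leads to compound 4 `NC1=NC2(CCSCC2)N(OCCCOc2ccccc2Cl)C(N)=N1` and puts chloro in place of bromo on an aromatic carbon, ortho to a large group (chloro in place of bromo on an aromatic carbon). No exchange of these two halogens has been measured here, so the evidence is indirect. One relevant step is no change at the digits printed from compound 1 to compound 3 (within the scatter) and lies within the scatter. Another is a 10-fold higher number from compound 2 to compound 3 (1.00 log units; beyond the scatter) and lies beyond it, but it removes a whole chloro as well as exchanging one halogen. The change in view is smaller, so no shift of that size is expected, and any shift beyond the scatter would be a surprise. The expected change is a 1.4-fold lower number from compound 3 to compound 4 (0.15 log units; within the scatter) and leans slightly toward a lower number. For compound 4 the estimated value is 7 nM in this assay as the central expectation. The expected range for compound 4 runs from 2 nM to 25 nM as a working span.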

Compound 4, half-maximal inhibitory concentration: 80 nM
Beside the measured number, compound 4's estimate is 11-fold (1.06 log units) below it, and the stated range ends below it.
By their numbers in this assay, from the lowest: compound 2; then compounds 1 and 3 (each within the scatter of the next); then compound 4.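

In this assay the exchange of one halogen for the other is not neutral at this place, on an aromatic carbon ortho to a large group: the step is an 8.0-fold higher number from compound 3 to compound 4 (0.90 log units; beyond the scatter) and lies beyond the scatter, so bromo and chloro cannot be treated as interchangeable here. Taking away the second chloro of the 2,3-dichlorophenyl gives an 80-fold higher number from compound 2 to compound 4 (1.90 log units; beyond the scatter) as the largest step in the set, and the comparison with the 3,4-dichlorophenyl gives an 8.0-fold higher number from compound 1 to compound 4 (0.90 log units; beyond the scatter), which leaves compound 4 as the weakest of the four, with a lone chloro on the ring falling short of bromo and of both dichlorophenyl patterns. Nothing available here bears on the reason for this gap between the two halogens.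

Still open, going by these compounds, is whether iodo, fluoro or methyl at this place would continue the order seen for bromo and chloro. Also open, on these data alone, is whether a second chloro added to the 2-bromophenyl of compound 3 would bring a gain of the size seen on going from compound 4 to compound 2.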